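The source may report more compounds than this note shows. Statements on the series, on what has been measured and on what is new or still open speak of the compounds shown alone.

Measured compounds in a functional assay on L6 cells (Rattus norvegicus) for inhibition; on this read-out lower numbers stand for stronger inhibition and higher numbers for weaker inhibition:
compound 1 `CC(C)c1c(C(=O)N2CCC[C@H](c3ccccc3)C2)nn(-c2ccc(F)cc2)c1CC[C@@H](O)C[C@@H](O)CC(=O)O`: 310 nM
compound 2 `CC(C)c1c(C(=O)N(C)Cc2cccc(F)c2)nn(-c2ccc(F)cc2)c1CC[C@@H](O)C[C@@H](O)CC(=O)O`: 1900 nM
compound 3 `COc1cccc(CNC(=O)c2nn(-c3ccc(F)cc3)c(OC[C@@H](O)C[C@@H](O)CC(=O)O)c2C(C)C)c1`: 8750 nM

Compound 3 stands highest of the three numbers and is therefore the weakest inhibitor of the set; compound 2 is nearest to it and compound 1 furthest, and both gaps lie beyond the scatter.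

Compound 4 `CC(C)c1c(C(=O)N(C)Cc2ccc(F)c(F)c2)nn(-c2ccc(F)cc2)c1OC[C@@H](O)C[C@@H](O)CC(=O)O` is not yet measured. Its change from compound 3 is (3,4-difluorobenzyl)(methyl)amino in place of (3-methoxybenzyl)amino on a carbonyl carbon. The shared core of compound 3 and compound 4 is kept; only the amide substituent on the carbonyl carbon is exchanged.

Within the data shown here, one measured step touches the same position: a 6.1-fold higher number from compound 1 to compound 2 (0.79 log units; beyond the scatter). That step put a (3-fluorobenzyl)(methyl)amino group in place of 3-phenylpiperidin-1-yl and weakened inhibition modestly, but it does not describe the present exchange, and compound 2 carries a different core from compound 3. Compound 2, with its benzyl-methyl amide, does sit well below compound 3 in number, which is the only indirect hint available. The expected outcome is a modest step toward stronger inhibition, a 2.2-fold lower number from compound 3 to compound 4 (0.34 log units; beyond the scatter), with wide uncertainty. Compound 4 is estimated at 4000 nM, range 1500 nM to 12000 nM.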

Compound 4, half-maximal inhibitory concentration: 4570 nM
Estimate against measurement, compound 4: 1.1-fold (0.06 log units) below; low and high end bracket the measured number.
By their numbers in this assay, from the lowest: compound 1; then compound 2; then compounds 4 and 3 (each within the scatter of the next).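

On the shared core of compound 3 and compound 4, this assay gives a 1.9-fold lower number from compound 3 to compound 4 (0.28 log units; within the scatter). At this carbonyl carbon, the read-out therefore does not separate (3-methoxybenzyl)amino from (3,4-difluorobenzyl)(methyl)amino, even though the exchange takes the counted hydrogen-bond donors and acceptors of the group from one each to none and replaces the methoxy group with two fluorines. No measurement of any property of these groups is available to explain this result.

On these data alone, the exchange alters the amide nitrogen and the ring substituents together, so the contribution of each remains open, and a (3-methoxybenzyl)(methyl)amino group on the same carbonyl carbon would begin to separate them. As far as these compounds go, it also remains open whether 3-phenylpiperidin-1-yl, the group carried by compound 1 at 310 nM, would give a similar number on the core of compound 3 and compound 4.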